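Extending the Alkoxy Chain on a Shared Core

The compounds below may be only part of what the source reports. "The series", "measured", "known", "first", "only" and "open" are said of these compounds alone.

Of the compounds shown here, three that share a core have been measured in a functional assay on SMMC-7721 cells (Homo sapiens) for cytotoxicity, read by MTT assay, with a stated time of 72 h; a higher number here means a weaker inhibitor, a lower number a stronger inhibitor. Compound 1 `CCCOCNc1n[n+]([O-])c2cc(OC)ccc2[n+]1[O-]` gives 1070 nM in this assay. Compound 2 `O=[N+]([O-])c1cccc(COCNc2n[n+]([O-])c3ccccc3[n+]2[O-])c1` gives 520 nM in this assay. Compound 3 `COCNc1n[n+]([O-])c2ccccc2[n+]1[O-]` gives 2480 nM in this assay, which is the highest of the three numbers; its nearest neighbour is compound 1, whose number is lower by a margin beyond the scatter, and compound 2 stands further off, again beyond the scatter. Compound 3 is thus the weakest inhibitor among the three.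

Compound 4 `CC(C)CCOCNc1n[n+]([O-])c2ccccc2[n+]1[O-]` has not yet been measured in this assay. It differs from compound 3 in one place: isobutyl in place of hydrogen on a saturated chain carbon bound to an oxygen on a saturated carbon. Read one bond further out, the methoxy of compound 3 becomes an isopentyloxy in compound 4.

For the measured compounds named here, no measured pair differs in exactly this way, so the size of the step is uncertain. The two compounds with a larger group on the oxygen, compound 1 and compound 2, both show lower numbers than compound 3, though compound 1 also carries a methoxy on its core. Compound 4 is therefore expected to show a modest step downward from compound 3 in this assay, a 2.5-fold lower number from compound 3 to compound 4 (0.39 log units; beyond the scatter), with the estimate for compound 4 at 1000 nM, in a range from 400 nM to 2500 nM.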

Compound 4, half-maximal inhibitory concentration: 2860 nM
Compound 4: the middle estimate sits 2.9-fold (0.46 log units) below what was measured; the whole stated range lies below it.
By their numbers in this assay, from the lowest: compound 2; then compound 1; then compounds 3 and 4 (each within the scatter of the next).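

In this assay, the step of a 1.2-fold higher number from compound 3 to compound 4 (0.06 log units; within the scatter) shows that isobutyl in place of hydrogen on this saturated chain carbon, which turns methoxy into isopentyloxy, leaves the number unchanged within the scatter. At this position, then, a longer branched saturated chain on the oxygen does not by itself give a number like that of compound 2 (520 nM), which shares the core of compound 4 (2860 nM) and carries a nitro-substituted benzyl group on the same oxygen. No measurement shown here explains why the step is so small.

On these data alone, the value of compound 1 (1070 nM) cannot be assigned to its propyl group alone, since that compound also carries a methoxy on its core, so the effect of a straight propyl or longer unbranched chain on the shared core stays open. Also open, as far as these compounds go, is whether an unsubstituted benzyl group, or an amine or a carboxylic acid at the end of the chain, would move the number in this assay as the isobutyl change does not.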